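Methyl in place of hydrogen on the chain of compound 2

The source may hold more compounds than are shown below. What is called first, only, known or untested is meant among the compounds shown, and "the series" means these compounds.

Two compounds of this series have numbers in an assay for inhibition of Amine oxidase [flavin-containing] A (Bos taurus), read by fluorescence, with a stated time of 30 min; on this read-out higher numbers stand for weaker inhibition and lower numbers for stronger inhibition. Compound 1 `CCn1ccc(N2C[C@H](CO)OC2=O)c1` gives 3 nM in this assay. Within the data shown here, compound 2 `Cn1ccc(N2C[C@H](CN)OC2=O)c1` gives 10 nM in this assay, the higher of the two numbers, with compound 1 as its only neighbour, and the gap between compound 1 and compound 2 lies beyond the usual scatter. These two compounds differ in more than one place, so no single step can be read from them.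

Compound 3 `CCn1ccc(N2C[C@H](CN)OC2=O)c1` has not yet been measured in this assay. It differs from compound 2 by methyl in place of hydrogen on a saturated chain carbon bound to an aromatic nitrogen. Among the measured compounds shown here, no measured pair carries this change on its own, so its size in this assay is unknown from the data. The estimated step is a 1.7-fold lower number from compound 2 to compound 3 (0.22 log units; within the scatter), a modest move toward a lower number and thus stronger inhibition, which may still fall within the scatter, because compound 1 carrying ethyl gives 3 nM while also bearing a different group on the other chain. Compound 3 is expected to give about 6 nM in this assay, with a range from 2 nM to 20 nM.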

Compound 3, inhibition constant: 130 nM
For compound 3 the middle estimate is 22-fold (1.34 log units) below the measured one; the measured number lies above the stated range.
By their numbers in this assay, from the lowest: compound 1; then compound 2; then compound 3.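

In this assay, the step of a 13-fold higher number from compound 2 to compound 3 (1.11 log units; beyond the scatter) shows that methyl in place of hydrogen on a saturated chain carbon bound to an aromatic nitrogen is a large change at this position, and that it moves toward weaker inhibition when the amino group is present. With ethyl held constant, amino in place of hydroxy on a saturated chain carbon bound to a saturated ring carbon gives a 43-fold higher number from compound 1 to compound 3 (1.64 log units; beyond the scatter) and so shows that ethyl alone does not fix the number: compound 1, which carries ethyl with hydroxy, gives 3 nM in this assay. No measurement in hand offers an explanation for either step.

A compound carrying methyl together with hydroxy would complete the set and show whether the methyl to ethyl change has the same size with hydroxy as with amino, a question the three compounds shown cannot answer. On these data alone, how a longer chain such as propyl on the aromatic nitrogen, or a carboxylic acid in place of the amino group, would read also remains open.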